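Swapping Benzyl for Isopropyl on the Ring Nitrogen

A few compounds are considered here, and "the series" means these few. Any claim that something is new, unique, unknown or untested is made for them only; others in the source may bear on it.

Compound 1 `CC(C)n1c(SCc2ccccc2Cl)nc2cc(NC(=O)C3CC3)ccc21`: 6300 nM
Compound 2 `COc1ccc([N+](=O)[O-])cc1CSc1nc2cc(NC(=O)NC(C)(C)C)ccc2n1Cc1ccccc1`: 28 nM

Both were tested in an assay on isolated protein for inhibition of Gonadotropin-releasing hormone receptor (Homo sapiens); on this read-out lower numbers stand for stronger inhibition and higher numbers for weaker inhibition. Compound 2 gives the lower of the two numbers, and compound 1 sits far above it, well beyond the usual scatter. Compound 3 `COc1ccc([N+](=O)[O-])cc1CSc1nc2cc(NC(=O)NC(C)(C)C)ccc2n1C(C)C` differs from compound 2 in one place: isopropyl in place of benzyl on an aromatic nitrogen. Going by the values given here, no measured pair shows this swap on its own, so the size of the step in this assay can only be guessed; a moderate rise in the number, meaning a weaker inhibitor, seems most likely. For compound 3 the expected step is a 2.9-fold higher number from compound 2 to compound 3 (0.46 log units; beyond the scatter). Compound 3 is therefore estimated at 80 nM, within a range of 20 nM to 400 nM.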

Compound 3, half-maximal inhibitory concentration: 62 nM
Compound 3: middle estimate off by 1.3-fold (0.11 log units), on the high side, and the stated range covers the measured number.
By their numbers in this assay, from the lowest: compound 2; then compound 3; then compound 1.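

In this assay the step from benzyl to isopropyl on this ring nitrogen can now be read on its own: a 2.2-fold higher number from compound 2 to compound 3 (0.35 log units; beyond the scatter) is a modest change. Strong inhibition therefore survives the loss of the benzyl ring, with compound 3 at 62 nM. Nothing available explains the size of this step.

On these data alone, whether a smaller group such as methyl, or a longer chain carrying an amine, would be tolerated on this nitrogen stays open. Compound 1, at 6300 nM, also carries isopropyl but differs from compound 3 in several other places, so its much higher number cannot be traced to any one of them.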